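The source may hold more compounds than are shown below. What is called first, only, known or untested is meant among the compounds shown, and "the series" means these compounds.

Of the compounds shown here, three of a shared core have been measured so far in an ADME assay on Vero cells (Chlorocebus sabaeus) for cytotoxicity, read by MTT assay, with a stated time of 72 h; a lower number here means that less compound is tolerated, a higher number that more compound is tolerated. Compound 1 `COc1ccc(/C=C/C(=O)c2ccc(OCC(O)CNCCNc3ccnc4cc(Cl)ccc34)cc2)cc1OC` gives 10200 nM. Compound 2 `COc1cc(/C=C/C(=O)c2ccccc2OCC(=O)NCCNc2ccnc3cc(Cl)ccc23)cc(OC)c1OC` gives 3920 nM. Compound 3 `O=C(COc1ccccc1C(=O)/C=C/c1ccc(Cl)cc1)NCCNc1ccnc2cc(Cl)ccc12` gives 4980 nM. Among these three numbers compound 3 holds the second highest; its nearest neighbour is compound 2, whose number lies within the scatter of it, while compound 1 sits two steps away at the higher side, beyond the scatter.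

Among the measured compounds shown here, the only single-point step so far is a 1.3-fold higher number from compound 2 to compound 3 (0.10 log units; within the scatter), a 4-chlorophenyl in place of 3,4,5-trimethoxyphenyl on a double-bonded chain carbon bound to a double-bonded chain carbon, and it did not move the number beyond the scatter.

Compound 4 `CC(=O)c1ccccc1OCC(=O)NCCNc1ccnc2cc(Cl)ccc12` is the next compound to be measured. It differs from compound 3 in this way: methyl in place of 2-(4-chlorophenyl)ethenyl on a carbonyl carbon. For the measured compounds named here, no measured step removes the whole 2-(4-chlorophenyl)ethenyl group; the step from compound 2 to compound 3 only swapped the ring at its end, so it bears on this change only loosely. The expectation is therefore uncertain, leaning to a modestly higher number, roughly a 1.5-fold higher number from compound 3 to compound 4 (0.18 log units; within the scatter). For compound 4 the estimate in this assay is 7500 nM, with a range from 2500 nM to 22000 nM.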

Compound 4, half-maximal cytotoxic concentration: 106000 nM
Beside the measured number, compound 4's estimate is 14-fold (1.15 log units) below it; measured number outside the range, above it.
By their numbers in this assay, from the lowest: compounds 2 and 3 (each within the scatter of the next); then compound 1; then compound 4.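

In this assay, among the compounds shown here, the group on the carbonyl carbon matters far more than the earlier compounds could show: exchanging 2-(4-chlorophenyl)ethenyl, with its 9 heavy atoms and its aromatic ring, for methyl gives a 21-fold higher number from compound 3 to compound 4 (1.33 log units; beyond the scatter) and places compound 4 well clear of the others. The earlier change at this group, a 1.3-fold higher number from compound 2 to compound 3 (0.10 log units; within the scatter), swapped only the ring at the end of the chain and stayed within the scatter, whereas removing the whole group, ring and double bond together, moves the number by a large step. Nothing measured here accounts for this jump, and its size is all that can be stated.

The compounds shown leave open which part of the removed group counts, since a 2-(4-chlorophenyl)ethyl group would keep the ring without the double bond, and a plain ethenyl group would keep the double bond without the ring. Also open, on these data alone, is whether a longer plain carbon chain in place of methyl on the carbonyl carbon would keep the number as high or bring it back towards that of compound 3.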